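Series notes: hydroxymethyl in place of hydrogen at the amide carbon

The source may hold more compounds than are shown below. What is called first, only, known or untested is meant among the compounds shown, and "the series" means these compounds.

Measured so far:
Compound 1 `O=C(CN(c1nc(Cl)nc2[nH]cnc12)C1CC1)N[C@@H](CO)C(=O)OCc1ccccc1` in a functional assay on the whole organism (Tail, strain ICR) with Mus musculus as the target, in the tail flick test, with a stated time of 60 min, at a dose of 25 umol/kg by the oral route (on this read-out higher numbers stand for a stronger effect at the one dose given and lower numbers for a weaker effect), gives 34.2%.
Compound 2 `O=C(CN(c1ncnc2c1ncn2C1CCCCO1)C1CC1)N[C@@H](CCC(=O)OCc1ccccc1)C(=O)OCc1ccccc1` gives 34.7%.
Compound 3 `O=C(CN(c1ncnc2c1ncn2C1CCCCO1)C1CC1)NCC(=O)OCc1ccccc1` gives 40.4%.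

Compound 3 holds the largest of the three numbers, yet both gaps to it lie within the scatter; the step of a number 5.7 percentage points higher from compound 2 to compound 3 (within the scatter) is one of them, and compound 1 sits about as close. Compound 4 `O=C(CN(c1ncnc2c1ncn2C1CCCCO1)C1CC1)N[C@@H](CO)C(=O)OCc1ccccc1` differs from compound 3 by hydroxymethyl in place of hydrogen on a saturated chain carbon bound to an amide-type nitrogen and a carbonyl carbon. For the measured compounds named here, the only measured step at this place, a number 5.7 percentage points higher from compound 2 to compound 3 (within the scatter), exchanged a larger chain for hydrogen and stayed within the scatter. Going by the values given here, compound 1 carries the same hydroxymethyl group but on a different core, so no step to it is available. A shift beyond the scatter is therefore not expected; the estimated step is a number 3.4 percentage points lower from compound 3 to compound 4 (within the scatter). For compound 4 the estimate is 37%, with a range from 26% to 48%.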

Compound 4, a percentage reported as activity, at one dose (the size of the read-out at that dose, not a potency): 46.7%
Compound 4: the middle estimate sits 9.7 percentage points below what was measured; the range from low to high includes it.
By their numbers in this assay, from the lowest: compounds 1, 2, 3 and 4 (each within the scatter of the next, the first and the last beyond it).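

At the saturated chain carbon bound to an amide-type nitrogen and a carbonyl carbon, hydroxymethyl in place of hydrogen gives a number 6.3 percentage points higher from compound 3 to compound 4 (within the scatter) in this assay, so the two groups are not separated at this position. For the compounds shown here, the first step at this carbon to clear the scatter is a number 12 percentage points higher from compound 2 to compound 4 (beyond the scatter), with hydroxy in place of (benzyloxycarbonyl)methyl on the side chain. No measurement at hand explains these numbers. Open, on these data alone, is how an amine, a carboxylic acid or a longer chain at this carbon would read out.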